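The compounds below may be only part of what the source reports. "The series", "measured", "known", "first", "only" and "open" are said of these compounds alone.

Of the compounds shown here, two built on one shared core have been tested in a functional assay on U-937 cells (Homo sapiens) for antiproliferative activity, read by CCK-8 assay, with a stated time of 48 h; on this read-out lower numbers stand for stronger inhibition and higher numbers for weaker inhibition. Compound 1, `Cc1cc(Nc2cc(N3CCN(C)CC3)nc(Nc3ccc(F)c(F)c3)n2)n[nH]1`, gives 29.9 nM. Compound 2, `Cc1cc(Nc2cc(N3CCN(C)CC3)nc(Nc3ccc(Cl)c(Cl)c3)n2)n[nH]1`, gives 17.9 nM. Within the data shown here, of these two numbers compound 1 carries the higher one, and the step of a 1.7-fold lower number from compound 1 to compound 2 (0.22 log units; within the scatter) is its only comparison so far. Compound 3, `Cc1cc(Nc2cc(N3CCN(C)CC3)nc(Nc3cccc(F)c3)n2)n[nH]1`, has not been measured yet. It differs from compound 1 by hydrogen in place of fluoro on an aromatic carbon. Among the measured compounds shown here, the single measured step, a 1.7-fold lower number from compound 1 to compound 2 (0.22 log units; within the scatter), exchanged one pair of halogens for another on the same aromatic ring and moved the number by less than the usual scatter. For the measured compounds named here, no measured pair removes a halogen outright, so there is no direct precedent for this change. On that thin basis a step of little size is expected, if anything a slight weakening. The estimate for compound 3 in this assay is 40 nM, with a range from 15 nM to 110 nM. This corresponds to an expected 1.3-fold higher number from compound 1 to compound 3 (0.13 log units; within the scatter).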

Compound 3, half-maximal inhibitory concentration: 33.1 nM
Compound 3: the middle estimate sits 1.2-fold (0.08 log units) above what was measured; low and high end bracket the measured number.
By their numbers in this assay, from the lowest: compounds 2, 1 and 3 (each within the scatter of the next).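

Going from 3,4-difluorophenyl to 3-fluorophenyl in this assay gives a 1.1-fold higher number from compound 1 to compound 3 (0.04 log units; within the scatter), so in the compounds shown, the aromatic carbon ortho to a fluoro group and para to a large group can carry hydrogen instead of fluoro without a step beyond the scatter. The broader exchange of 3,4-dichlorophenyl for 3-fluorophenyl gives a 1.8-fold higher number from compound 2 to compound 3 (0.27 log units; within the scatter), and this step also stays within the scatter. No experimental evidence is available to explain why these numbers stay so close.

Going by these compounds, a plain phenyl group, with no halogen on the ring, remains open, since compound 3 still keeps one fluoro group. Also open, on these data alone, is how a methoxy group, an amine or a carboxylic acid would behave at the place that compound 3 leaves with hydrogen.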